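A few compounds are considered here, and "the series" means these few. Any claim that something is new, unique, unknown or untested is made for them only; others in the source may bear on it.

This series shares one core, and a single measurement is missing from the comparison. In an ADME assay on MDCK cells (Canis lupus familiaris) for permeability, in the apical to basolateral direction (a higher number here means that the compound crosses the layer faster, a lower number that the compound crosses the layer more slowly), compound 1 `CC(C)C(/C=C1\NC(=O)NC1=O)c1ccc(-c2ccc3cccc(F)c3c2)[nH]c1=O` gives 12.3 10^-6 cm/s and compound 3 `CC(C)/C(=C1\C(=O)NC(=O)N1C)c1ccc(-c2ccc3cccc(F)c3c2)[nH]c1=O` gives 6.85 10^-6 cm/s, two values within the usual scatter of each other. Compound 2 `CC(C)C(c1ccc(-c2ccc3cccc(F)c3c2)[nH]c1=O)C1NC(=O)NC1=O` offers no such anchor, and its entry reads "not determined" (no result reported). Its standing on this read-out is therefore unknown.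

Compound 4 `CC(C)C(CC1NC(=O)NC1=O)c1ccc(-c2ccc3cccc(F)c3c2)[nH]c1=O` has yet to be measured. It is related to compound 2 by one small structural change: (2,5-dioxoimidazolidin-4-yl)methyl in place of 2,5-dioxoimidazolidin-4-yl on a saturated chain carbon bound to an aromatic carbon and a saturated chain carbon. In other words, (2,5-dioxoimidazolidin-4-yl)methyl stands in place of 2,5-dioxoimidazolidin-4-yl on the same saturated chain carbon.

Going by the values given here, no measured pair in this set shows what such a change does, so the size of the step must remain a cautious expectation. No step beyond the scatter is expected in this assay, and no direction can be favoured. Among the compounds with values here, the only numbers to lean on are those of compound 1 at 12.3 10^-6 cm/s and compound 3 at 6.85 10^-6 cm/s.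

For compound 4 the expected value is 8 10^-6 cm/s, with an estimated range from 3 10^-6 cm/s to 20 10^-6 cm/s.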

Compound 4, apparent permeability: 17.1 10^-6 cm/s
Beside the measured number, compound 4's estimate is 2.1-fold (0.33 log units) below it, and the stated range covers the measured number.
By their numbers in this assay, from the lowest: compounds 3, 1 and 4 (each within the scatter of the next, the first and the last beyond it).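

Compound 4 gives this series a measured number in this assay for a compound with the (2,5-dioxoimidazolidin-4-yl)methyl group on the saturated chain carbon. Set against compound 1, which carries a group with the same heavy-atom count at that place, the result is a 1.4-fold higher number from compound 1 to compound 4 (0.14 log units; within the scatter), so this assay does not tell these two groups apart. The step from 2,5-dioxoimidazolidin-4-yl to (2,5-dioxoimidazolidin-4-yl)methyl cannot be read, and nothing shown here offers an explanation for the number of compound 4.

The compounds shown leave open how a longer chain between the saturated chain carbon and the same ring would read in this assay. They also leave open what a carboxylic acid or an amine in place of that ring would give.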